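Dropping the methoxy: from compound 1 to compound 4

The source may report more compounds than this note shows. Statements on the series, on what has been measured and on what is new or still open speak of the compounds shown alone.

Compound 1 `COc1cccc(CNC(=O)c2nc(Br)c3cccnc3c2N[C@H]2CC[C@H](N)CC2)c1` gives 6000 nM in a functional assay on HCT-116 cells (Homo sapiens) for cytotoxicity, read by MTT assay, with a stated time of 72 h; a lower number here means a stronger inhibitor, a higher number a weaker inhibitor.
Compound 2 `O=C(NCc1ccc(F)cc1)c1nc(Br)c2cccnc2c1NCCCNc1c(C(=O)NCc2ccc(F)cc2)nc(Br)c2cccnc12` gives > 20000 nM in this assay, which is a limit of the assay and not a number.
Compound 3 `O=C(NCc1ccc(F)cc1)c1nc(NCCO)c2cccnc2c1O` has "not determined" (no result reported) in this assay.

Going by the values given here, compound 1 is thus the only compound of the three with a measured number; one further entry sits at the limit of > 20000 nM in this assay, at which 1 of the 3 values shown sits, and one carries no result. Among the compounds with values here, no pair of measured compounds differs in one place, so no measured step is available. Compound 4 `N[C@H]1CC[C@H](Nc2c(C(=O)NCc3ccccc3)nc(Br)c3cccnc23)CC1` is not yet measured and differs from compound 1 by hydrogen in place of methoxy on an aromatic carbon. He expects a step from compound 1 to compound 4 of a 1.2-fold higher number from compound 1 to compound 4 (0.07 log units; within the scatter), within the usual scatter, in no clear direction. Compound 4 is estimated at 7000 nM, between 2500 nM and 20000 nM.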

Compound 4, half-maximal inhibitory concentration: 7000 nM
Estimate against measurement, compound 4: no gap at the digits printed; low and high end bracket the measured number.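

Going by these compounds alone, the first step that can be read in this assay is a 1.2-fold higher number from compound 1 to compound 4 (0.07 log units; within the scatter), so at this aromatic carbon, meta to a large group, compound 1 and compound 4 stand within the scatter of each other. Within the data shown here, the methoxy is thus not required for the cytotoxicity read here, which the earlier compounds could not show, since no two of them differed in one place. No measurement shown bears on a cause for this result.

On these data alone, whether a hydroxyl, an amine or a carboxylic acid on this carbon would give a step beyond the scatter stays open. So does the effect of a methoxy on another carbon of this ring.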